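Swapping the Thiophene Arm: What to Expect for Compound 4

The source may report more compounds than this note shows. Statements on the series, on what has been measured and on what is new or still open speak of the compounds shown alone.

Of the compounds shown here, three built on one shared core have been tested in a functional assay on MCF7 cells (Homo sapiens) for antiproliferative activity, read by MTT assay; on this read-out higher numbers stand for weaker inhibition and lower numbers for stronger inhibition. Compound 3 `COc1ccc([C@@H]2[C@@H](C(=O)c3cccs3)C(=O)N2c2cc(OC)c(OC)c(OC)c2)cc1` gives 950 nM. Compound 1 `COc1ccc([C@@H]2[C@@H](C(O)c3ccsc3)C(=O)N2c2cc(OC)c(OC)c(OC)c2)cc1` gives 990 nM, and compound 2 `COc1ccc([C@@H]2C(c3ccsc3)C(=O)N2c2cc(OC)c(OC)c(OC)c2)cc1` gives 60 nM. Compound 3 thus holds the second highest of the three numbers: its nearest neighbour is compound 1, whose number sits within the scatter of it, and its furthest is compound 2, whose number lies well below both.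

Within the data shown here, only one single-point step has been measured: a 1.0-fold lower number from compound 1 to compound 3 (0.02 log units; within the scatter). Exchanging the hydroxy(thiophen-3-yl)methyl arm for a (thiophen-2-yl)carbonyl arm on the saturated ring carbon left the number essentially unchanged.

Compound 4 `COc1ccc([C@@H]2[C@@H](C(O)c3ccc(C)s3)C(=O)N2c2cc(OC)c(OC)c(OC)c2)cc1` differs from compound 3 as follows: hydroxy(5-methylthiophen-2-yl)methyl in place of (thiophen-2-yl)carbonyl on a saturated ring carbon. The step of a 1.0-fold lower number from compound 1 to compound 3 (0.02 log units; within the scatter) bears on this, since it covers the swap between a carbonyl link and a hydroxymethyl link at the same ring carbon and showed no movement beyond the scatter. Among the measured compounds shown here, no measured step covers the methyl on the thiophene ring or the move of the attachment point on that ring, so that part remains open. The expected step is therefore a 1.1-fold higher number from compound 3 to compound 4 (0.02 log units; within the scatter), within the scatter. In this assay compound 4 is estimated at 1000 nM, with a range from 400 nM to 2500 nM.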

Compound 4, half-maximal inhibitory concentration: 1260 nM
The estimate for compound 4 lay 1.3-fold (0.10 log units) below the measured number, and the stated range covers the measured number.
By their numbers in this assay, from the lowest: compound 2; then compounds 3, 1 and 4 (each within the scatter of the next).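

In this assay, placing hydroxy(5-methylthiophen-2-yl)methyl in place of (thiophen-2-yl)carbonyl on the saturated ring carbon gives a 1.3-fold higher number from compound 3 to compound 4 (0.12 log units; within the scatter). Among these compounds, the hydroxy link can also be held constant: with 5-methylthiophen-2-yl in place of thiophen-3-yl, the result is a 1.3-fold higher number from compound 1 to compound 4 (0.10 log units; within the scatter), the first measured change to the thiophene ring itself rather than to the link alone. Together with the earlier step, this shows that all three arms tried on this ring carbon give numbers within the scatter of one another, so neither the link nor these thiophene variations produce a readable difference here, and no data on the reason are available.

As far as these compounds go, the step from compound 1 to compound 4 carries the added methyl and the moved attachment point together, so the separate contribution of each remains unknown, and the two could be pulling in opposite directions. Also open, from the compounds shown here alone, is whether a clearly different group on the thiophene ring, such as an amine or a carboxylic acid, would move the number beyond the scatter.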